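The source may report more compounds than this note shows. Statements on the series, on what has been measured and on what is new or still open speak of the compounds shown alone.

Measured in a physicochemical assay for lipophilicity, read by HPLC, with a stated time of 90 min, tested at 100 uM; a lower number here means a more polar compound, a higher number a more lipophilic compound:
compound 1 `O=C(Nc1ccc(C(F)(F)F)cc1)NC1CCN(C(=O)C2=COCC2)CC1` gives 3.37;
compound 2 `O=C(Nc1ccc(OC(F)(F)F)cc1)NC1CCN(C(=O)C2=COCC2)CC1` gives 3.49;
compound 3 `O=C(Nc1ccc(C(F)(F)F)c(F)c1)NC1CCN(C(=O)[C@@H]2CCOC2)CC1` gives 3.41.

Compound 4 `O=C(Nc1ccc(OC(F)(F)F)c(F)c1)NC1CCN(C(=O)[C@@H]2CCOC2)CC1` awaits measurement in this assay. It differs from compound 3 in one place: trifluoromethoxy in place of trifluoromethyl on an aromatic carbon. The same kind of change separates compound 1 from compound 2: trifluoromethoxy in place of trifluoromethyl on an aromatic carbon. The two places are not identical in their surroundings: in compound 3 the changed carbon is ortho to a fluoro group (1 heavy atom), whereas in compound 1 it is only para to a large group. The difference between the core of compound 3 and the core of compound 1 is not broken down here. Going by the values given here, the one measured instance of this kind of change gave a number 0.12 log units higher from compound 1 to compound 2 (within the scatter). In this assay the step is expected to be a number 0.12 log units higher from compound 3 to compound 4 (within the scatter), resting on that single measured step. Compound 4 is therefore estimated at 3.53, most likely between 3.25 and 3.8.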

Compound 4, partition coefficient: 3.59
Compound 4: the middle estimate sits 0.06 log units below what was measured; the range from low to high includes it.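

In this assay, trifluoromethoxy in place of trifluoromethyl gives a number 0.18 log units higher from compound 3 to compound 4 (within the scatter), and on the core of compound 1 the same change gives a number 0.12 log units higher from compound 1 to compound 2 (within the scatter); both steps are within the scatter, so on neither core does the change separate the two compounds measurably. This shows that the two cores agree in that respect, but with only two instances it does not establish a size for the step, or show whether the carbon being ortho to a fluoro group matters. Nothing available bears on why the steps look as they do.

The compounds shown leave open how this core would respond to a nitrile or a methoxy group in the same place. They also leave open whether the step would carry over to compounds bearing an amine or a carboxylic acid.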